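Isopropyl for Cyclopropylmethyl: Expected Tolerance of Compound 4

This account rests on a few compounds, and the source may have more. Where it says the series, first, only, none or still open, it means among the compounds named here.

Measured compounds in an ADME assay on HeLa cells (Homo sapiens) for cytotoxicity, read by ATP content, with a stated time of 3 days; a lower number here means that less compound is tolerated, a higher number that more compound is tolerated:
Compound 1 `CS(=O)(=O)CCCn1c(Cn2c(=O)n(CC3CC3)c3ccncc32)cc2cc(Cl)ccc21` gives > 50000 nM in this assay, a limit of the assay rather than a number.
Compound 2 `N#CCCCn1c(Cn2c(=O)n(-c3ncccn3)c3ccncc32)cc2cc(Cl)ccc21` gives > 50000 nM in this assay, likewise a limit.
Compound 3 `CC(C)CCn1c(Cn2c(=O)n(C3CC3)c3ccncc32)nc2ncccc21` gives > 100000 nM in this assay, also a limit.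

Compound 1 thus stands where every measured compound of the set stands: at a limit of this assay, not at a number. Two of the three values sit at the limit of > 50000 nM in this assay, at which 2 of the 3 values shown sit, and one at the limit of > 100000 nM in this assay, at which 1 of the 3 values shown sits, so no value distinguishes compound 1 from compound 2 or compound 3. Among the compounds with values here, no step between two measured compounds that differ in one place is available, and none of the three measured values can be ordered against another.

Compound 4 `CC(C)n1c(=O)n(Cc2cc3cc(Cl)ccc3n2CCCS(C)(=O)=O)c2cnccc21` differs from compound 1 by isopropyl in place of cyclopropylmethyl on an aromatic nitrogen. Within the data shown here, with every measured value at a limit, no step of any size in this assay is indicated, and the step from compound 1 to compound 4 is expected to be none beyond the scatter, a number no higher from compound 1 to compound 4 (the limit leaves the size open). Compound 4 is therefore expected to sit at 50000 nM in this assay, within 20000 nM to 100000 nM, most likely again reported only as a limit.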

Compound 4, half-maximal cytotoxic concentration: > 50000 nM
Compound 4: a limit, no number (the forecaster's own chance of this, stated with the estimate: 80%); the middle value lies on the limit itself.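

Within the data shown here, compound 1 and compound 4 both stand at a limit in this assay, not at a number, so no step between them can be read. The compounds shown leave open where the half-maximal cytotoxic concentration of any of them lies, and whether isopropyl in place of cyclopropylmethyl changes it at all.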